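Cytotoxicity of a Biaryl Ether and Its Biphenyl Analogue

The source may report more compounds than this note shows. Statements on the series, on what has been measured and on what is new or still open speak of the compounds shown alone.

compound 1, `COc1ccc2c(c1)[C@@H](O)CN(C)C2`: > 100000 nM
compound 2, `CN1Cc2ccc(OCc3ccc(Oc4ccccc4)cc3)cc2[C@@H](O)C1`: 3400 nM

In an ADME assay on Vero cells (Chlorocebus sabaeus) for cytotoxicity, read by sulforhodamine B assay, with a stated time of 72 h (on this read-out higher numbers stand for weaker inhibition and lower numbers for stronger inhibition), compound 2 gives 3400 nM, the only number shown here. Compound 1 reaches only a limit, > 100000 nM, which is not a number (the limit of > 100000 nM in this assay, at which 1 of the 2 values shown sits). Compound 3, `COc1cccc(-c2ccc(COc3ccc4c(c3)[C@@H](O)CN(C)C4)cc2)c1`, differs from compound 2 by 3-methoxyphenyl in place of phenoxy on an aromatic carbon. No change of this kind has been measured here, so the step from compound 2 to compound 3 is expected to stay within the usual scatter: a 1.1-fold lower number from compound 2 to compound 3 (0.05 log units; within the scatter). For compound 3 the estimated value is 3000 nM, with an expected range from 1000 nM to 10000 nM.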

Compound 3, half-maximal inhibitory concentration: 10800 nM
Estimate against measurement, compound 3: 3.6-fold (0.56 log units) below; the measured number lies above the stated range.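

In this assay, putting 3-methoxyphenyl in place of phenoxy on this aromatic carbon, para to a large group, gives a 3.2-fold higher number from compound 2 to compound 3 (0.50 log units; beyond the scatter). This shows that the number responds to a change at this position, with the higher number meaning weaker inhibition of the cells. Nothing available here accounts for the step.

A plain phenyl at this place could show whether the step belongs to the loss of the phenoxy oxygen or to the added methoxy group. As far as these compounds go, how an amine or a carboxylic acid would read here remains open.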